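The compounds below may be only part of what the source reports. "The series", "measured", "known", "first", "only" and "open" are said of these compounds alone.

Compound 1 `COc1ccc2nccc(C3CN(CCCNCc4cc5ccccc5[nH]4)C(=O)O3)c2c1` and compound 2 `O=C1OC(c2ccnc3ccccc23)CN1C1CCN(Cc2cc3ccccc3[nH]2)CC1` share the same five-membered core, which carries a basic amine on one side and an aromatic group on a saturated ring carbon on the other. In an in vitro functional assay on RBL cells for antagonist activity at C-C chemokine receptor type 8 (Homo sapiens), read by FLIPR and calcium flux (a higher number here means a weaker inhibitor, a lower number a stronger inhibitor), compound 1 gives 1580 nM. In this assay compound 2 gives 1000 nM. Compound 3 `O=C1OC(c2cccc3ccccc23)CN1C1CCN(Cc2cc3ccccc3[nH]2)CC1` carries naphthalen-1-yl where compound 2 carries quinolin-4-yl. For compound 3 only a limit of the assay is known, < 50200 nM, as recorded in the limit of < 50200 nM in this assay, at which 1 of the 3 values shown sits. The step that the limit leaves unreadable from compound 2 to compound 3 is therefore of unknown size. Compound 4 `O=C1OC(c2ccncc2)CN1C1CCN(Cc2cc3ccccc3[nH]2)CC1` differs from compound 3 as follows: pyridin-4-yl in place of naphthalen-1-yl on a saturated ring carbon. Among the compounds with values here, no measured step gives a size for this change, because a step that the limit leaves unreadable from compound 2 to compound 3 ends at a limit rather than a number. What can be said is that compound 2, with a nitrogen-containing aromatic ring at this carbon, gives 1000 nM, and compound 4 keeps such a ring while losing the second fused ring. For compound 4 a potency near that of compound 2, or somewhat weaker, is expected. The estimated step is therefore a step that the limit leaves unreadable from compound 3 to compound 4. The estimate for compound 4 is 3000 nM, with an expected range from 800 nM to 15000 nM.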

Compound 4, half-maximal inhibitory concentration: < 50200 nM
Compound 4 gave a limit, no number (the forecaster's own chance of this, stated with the estimate: 25%); the middle value lies beyond the limit too.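

Compound 3 and compound 4 each give a limit, not a number: the limit of < 50200 nM in this assay, at which 2 of the 4 values shown sit. Within the data shown here, no step from compound 2 or compound 3 to compound 4 can be read. The compounds shown leave open how far the potency moves when pyridin-4-yl or naphthalen-1-yl stands in place of quinolin-4-yl.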